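Switching a thiazole for a pyrrolidine on an antiproliferative counter-screen

The source may report more compounds than this note shows. Statements on the series, on what has been measured and on what is new or still open speak of the compounds shown alone.

Compound 1, `COc1ccc(-c2[nH]c3cc(OC)cc(OC)c3c(=O)c2I)cc1`: > 86200 nM in an ADME assay on BJ cells (Homo sapiens) for antiproliferative activity, with a stated time of 72 h; a lower number here means that less compound is needed, a higher number that more compound is needed for the effect
Compound 2, `COc1cc(OC)c2c(=O)cc(C(=O)Nc3cccc(N4CCCC4)c3)[nH]c2c1`: > 58600 nM in this assay

Compound 2 does not have a number here: its result is a limit of the assay, (the limit of > 58600 nM in this assay, at which 1 of the 2 values shown sits). Within the data shown here, the only other value shown, that of compound 1, is also a limit, (the limit of > 86200 nM in this assay, at which 1 of the 2 values shown sits). So nothing measured in this series yet gives a finite concentration, and no step between measured compounds can be drawn.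

Compound 3, `COc1cc(OC)c2c(=O)cc(C(=O)Nc3cccc(-c4nccs4)c3)[nH]c2c1`, is the untested partner of compound 2. The change is 1,3-thiazol-2-yl in place of pyrrolidin-1-yl on an aromatic carbon, meta to a large group. With both measured compounds sitting at limits, there is no basis for expecting a step beyond the scatter in either direction; the step from compound 2 to compound 3 is estimated as a step that the limit leaves unreadable from compound 2 to compound 3. Compound 3 is therefore expected to come out at 70000 nM, with a range from 20000 nM to 250000 nM, most likely again reported only as a limit.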

Compound 3, half-maximal effective concentration: > 54000 nM
Compound 3 gave a limit, no number; the forecaster's own chance of this, stated with the estimate: 80%; the middle value is on the limit's open side.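

Compound 2 and compound 3 both give only limits, not numbers, in this assay, so the step between them cannot be read. The compounds shown leave open whether 1,3-thiazol-2-yl in place of pyrrolidin-1-yl changes the concentration needed for the effect, and what finite concentration compound 1, compound 2 or compound 3 would need.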